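A few compounds are considered here, and "the series" means these few. Any claim that something is new, unique, unknown or untested is made for them only; others in the source may bear on it.

Measured in a functional assay on aorta with Alpha-1D adrenergic receptor (Rattus norvegicus) as the target; on this read-out lower numbers stand for an effect already at smaller amounts and higher numbers for an effect only at larger amounts of compound:
Compound 1 `O=c1c2ccccc2c(Cc2ccc(Cl)cc2)nn1-c1ccc([N+](=O)[O-])cc1`: 29000 nM.
Compound 2 `CSc1ccc(Cc2nn(C(C)(C)C)c(=O)c3ccccc23)cc1`: > 100000 nM, a limit of the assay and not a number.
Compound 3 `Oc1nnc(Cc2cccc3ccccc23)c2ccccc12`: 4400 nM.

Compound 2 stands at the limit of > 100000 nM in this assay, at which 1 of the 3 values shown sits, so its place among the three is known only as a bound, not as a value. Compound 4 `C=CCn1nc(Cc2ccc(SC)cc2)c2ccccc2c1=O` differs from compound 2 in one place: allyl in place of tert-butyl on an aromatic nitrogen. No step between measured compounds that differ in one place is available, so nothing shown tells how much a change on the aromatic nitrogen moves the half-maximal effective concentration in this assay. From compound 2 a step toward smaller amounts is expected, estimated as an at least 2.0-fold lower number from compound 2 to compound 4 (0.30 log units; that floor lies within the scatter). Compound 4 is therefore expected to give 50000 nM, with a range from 10000 nM to 200000 nM.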

Compound 4, half-maximal effective concentration: > 100000 nM
Compound 4: a limit, no number (the forecaster's own chance of this, stated with the estimate: 40%); middle value at least 2.0-fold (0.30 log units) from the limit.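

No step from compound 2 to compound 4 can be read in this assay, because both compounds sit at a limit of the assay and not at a number: the limit of > 100000 nM in this assay, at which 2 of the 4 values shown sit.

The compounds shown leave open how far allyl in place of tert-butyl on an aromatic nitrogen moves the half-maximal effective concentration in this assay.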